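From methoxy to methyl on compound 1

The source may report more compounds than this note shows. Statements on the series, on what has been measured and on what is new or still open speak of the compounds shown alone.

- Compound 1 `COc1ccc(-c2nn(-c3ccccc3)cc2CNc2ccc(Br)cc2)cc1` gives 7020 nM
- Compound 2 `COc1ccc(-c2nn(-c3ccccc3)cc2CNc2ccc(C)cc2)cc1` gives 8160 nM
- Compound 3 `COc1ccc(-c2nn(-c3ccccc3)cc2CNc2ccc(F)cc2)cc1` gives 5980 nM

These values come from a functional assay on MCF7 cells (Homo sapiens) for antiproliferative activity, read by MTT assay, with a stated time of 48 h (a lower number here means a stronger inhibitor, a higher number a weaker inhibitor), and lie close together. Compound 1 is not separated from either neighbour (a 1.2-fold higher number from compound 1 to compound 2 (0.07 log units; within the scatter); a 1.2-fold lower number from compound 1 to compound 3 (0.07 log units; within the scatter)). The remaining pair is no different (a 1.4-fold lower number from compound 2 to compound 3 (0.13 log units; within the scatter)).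

Compound 4 `Cc1ccc(-c2nn(-c3ccccc3)cc2CNc2ccc(Br)cc2)cc1` is still unmeasured. It has methyl in place of methoxy on an aromatic carbon, which turns 4-methoxyphenyl into 4-methylphenyl (methyl in place of methoxy on an aromatic carbon). Among the compounds with values here, no measured step touches the methoxy group, since all three swap bromo, methyl and fluoro at another spot. They offer only weak guidance, and no shift beyond the scatter is expected in this assay. The expected step is a 1.0-fold lower number from compound 1 to compound 4 (0.00 log units; within the scatter) (an estimate). Compound 4 is estimated at 7000 nM (3000 nM to 15000 nM).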

Compound 4, half-maximal inhibitory concentration: 6890 nM
Compound 4: middle estimate off by 1.0-fold (0.01 log units), on the high side; the range from low to high includes it.
By their numbers in this assay, from the lowest: compounds 3, 4, 1 and 2 (each within the scatter of the next).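

Replacing 4-methoxyphenyl with 4-methylphenyl removes the oxygen and its hydrogen-bond acceptor, yet in this assay the step stays within the scatter (a 1.0-fold lower number from compound 1 to compound 4 (0.01 log units; within the scatter)). Within the data shown here, this is the first view of this position, which the earlier compounds left untouched, and this one change does not separate the two compounds. Nothing measured here explains this result.

Going by these compounds, it remains open whether a group of another kind here, such as an amine or a carboxylic acid, would shift the number. On these data alone, it is also open whether the methyl swap would behave the same with fluoro in place of bromo.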